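A few compounds are considered here, and "the series" means these few. Any claim that something is new, unique, unknown or untested is made for them only; others in the source may bear on it.

Compound 1, `CCCC(C)n1ccc2cc(/C(C)=C/C(=O)Nc3ccccc3OCCCC(=O)O)ccc21`, gives 7.8 nM in an assay on Prostate gland for inhibition of steroid 5-alpha-reductase (Rattus norvegicus); a lower number here means a stronger inhibitor, a higher number a weaker inhibitor. Compound 2, `CCCC(CC)n1ccc2cc(/C(C)=C/C(=O)Nc3ccccc3OCCCC(=O)O)ccc21`, gives 9.3 nM in this assay. Compound 3, `CCCCC(CCCC)n1ccc2cc(/C(C)=C/C(=O)Nc3ccccc3OCCCC(=O)O)ccc21`, gives 21 nM in this assay.

Compound 3 thus gives the highest of the three numbers: from compound 2 the step is a 2.3-fold higher number from compound 2 to compound 3 (0.35 log units; beyond the scatter), and from compound 1 it is a 2.7-fold higher number from compound 1 to compound 3 (0.43 log units; beyond the scatter), both beyond the scatter, while a 1.2-fold higher number from compound 1 to compound 2 (0.08 log units; within the scatter) lies within it.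

Compound 4, `C/C(=C\C(=O)Nc1ccccc1OCCCC(=O)O)c1ccc2c(ccn2Cc2ccc(C(F)(F)F)cc2)c1`, has not yet been measured in this assay. It differs from compound 3 in one place: 4-(trifluoromethyl)benzyl in place of 1-butylpentyl on an aromatic nitrogen. All three measured steps concern the group on this same aromatic nitrogen, but each of them exchanges one saturated chain for another; none brings in a six-membered aromatic ring or fluorine. They show that the number rises modestly as the group grows from 1-methylbutyl or 1-ethylbutyl to 1-butylpentyl, and otherwise hardly moves. Going by the values given here, the replacement in compound 4 removes the largest of these chains, so a small fall in the number, near the edge of the scatter, is the expectation, with wide uncertainty because the aromatic ring has no precedent here. For compound 4 the expected step is a 1.8-fold lower number from compound 3 to compound 4 (0.24 log units; within the scatter). Compound 4 is therefore estimated at 12 nM, within the range 3 nM to 50 nM.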

Compound 4, half-maximal inhibitory concentration: 300 nM
Compound 4: middle estimate off by 25-fold (1.40 log units), on the low side; the measured number lies above the stated range.
By their numbers in this assay, from the lowest: compounds 1 and 2 (each within the scatter of the next); then compound 3; then compound 4.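

In this assay, the group on the aromatic nitrogen proves able to shift the number far more than the saturated chains showed: 4-(trifluoromethyl)benzyl gives large steps from all three chains (a 14-fold higher number from compound 3 to compound 4 (1.15 log units; beyond the scatter); a 32-fold higher number from compound 2 to compound 4 (1.51 log units; beyond the scatter); a 38-fold higher number from compound 1 to compound 4 (1.59 log units; beyond the scatter)), and each exceeds any step among those chains. The position that held all three saturated chains with only modest change responds strongly to this group, which brings a six-membered aromatic ring of carbon only and fluorine. Nothing available here gives a measured reason for this rise.

The compounds shown cannot separate the contribution of the aromatic ring from that of the trifluoromethyl group, since the two enter together in compound 4. An unsubstituted benzyl group would address that question, while a cyclohexylmethyl group would test a saturated ring on the same nitrogen, and a 4-chlorobenzyl group would show how the number responds when another atom takes the place of trifluoromethyl.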